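This account rests on a few compounds, and the source may have more. Where it says the series, first, only, none or still open, it means among the compounds named here.

Measured so far:
compound 1, `COc1cc(Oc2cccc(Nc3ccccc3)c2)cc(OC)c1CNCc1ccccc1`, 7490 nM
compound 2, `COc1cc(Oc2cccc(Nc3ccccc3)c2)cc(OC)c1CNCc1ccc(Cl)cc1`, 6340 nM

Both values come from a functional assay on SW-620 cells (Homo sapiens) for inhibition, read by MTT assay, with a stated time of 72 h; a higher number here means a weaker inhibitor, a lower number a stronger inhibitor. Going by the values given here, compound 1 gives the highest of the two numbers; its nearest neighbour is compound 2, and the only measured step, a 1.2-fold lower number from compound 1 to compound 2 (0.07 log units; within the scatter), does not rise above the scatter, so the two values cannot be told apart.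

Compound 3, `COc1cc(Oc2cccc(Nc3ccccc3)c2)cc(OC)c1CN(C)C`, has not been measured in this assay. Against compound 1 it differs by dimethylamino in place of benzylamino on a saturated chain carbon bound to an aromatic carbon. Among the compounds with values here, no measured step changes this part of the molecule: the step from compound 1 to compound 2 touches only the ring that is lost here, and it was within the scatter, so it gives no guidance on how the value responds to this change. The size and direction of the step in this assay are therefore open.

With nothing to lean on, compound 3 is estimated at 10000 nM, in a wide range from 3000 nM to 40000 nM, a step of a 1.3-fold higher number from compound 1 to compound 3 (0.13 log units; within the scatter) that is expected but uncertain.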

Compound 3, half-maximal inhibitory concentration: > 20000 nM
Compound 3 was reported as a limit; the forecaster's own chance of this, stated with the estimate: 20%; middle value at least 2.0-fold (0.30 log units) from the limit.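

In this assay compound 3 gives > 20000 nM, which is a limit of the assay and not an exact number. Unlike the chloro change on the benzyl ring, which stayed within the scatter, changing the whole amine group does register at this position: the data show an at least 2.6-fold higher number from compound 1 to compound 3 (0.42 log units; beyond the scatter), and an at least 3.1-fold higher number from compound 2 to compound 3 (0.49 log units; beyond the scatter), so both benzylamine compounds are stronger inhibitors than the dimethylamino compound. The true size of these steps cannot be read, because they rest on a limit: the limit of > 20000 nM in this assay, at which 1 of the 3 values shown sits.

The aromatic ring and the hydrogen-bond donor leave together in this change, so the compounds shown cannot say which of the two matters. Going by these compounds, a benzyl(methyl)amino group would keep the ring without the donor, while a methylamino group would keep the donor without the ring, and how either reads in this assay remains open.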